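The source may report more compounds than this note shows. Statements on the series, on what has been measured and on what is new or still open speak of the compounds shown alone.

Working notes on the series. Of the compounds shown here, two have been measured in a functional assay on HepG2 cells (Homo sapiens) for inhibition, with a stated time of 72 h; a lower number here means a stronger inhibitor, a higher number a weaker inhibitor. Compound 1, `O=C(Nc1ccccc1)Nc1nc(Sc2c[nH]c3ccccc23)cc(N2CCCC2)n1`, gives in this assay 11400 nM. Compound 2, `Cc1cc(Cl)ccc1NC(=O)Nc1nc(Nc2ccccc2)cc(Sc2c[nH]c3ccccc23)n1`, gives in this assay 8370 nM. On these two numbers compound 2 holds the lowest value, but compound 1 sits within the scatter of it, so no order between the two can be stated. Among the compounds with values here, the two structures differ in more than one place and no single step between them can be set out.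

The next compound, compound 3, `Cc1cc(Cl)ccc1NC(=O)Nc1nc(Sc2c[nH]c3ccccc23)cc(N2CCCC2)n1`, has not yet been measured in this assay. It departs from compound 2 in one place: pyrrolidin-1-yl in place of anilino on an aromatic carbon. Within the data shown here, no measured pair isolates this change, so there is no direct guide to its size or direction.

With nothing to draw on beyond the shared core and the closeness of both measured values, the step from compound 2 to compound 3 is expected to be small, a 1.1-fold higher number from compound 2 to compound 3 (0.05 log units; within the scatter), not clearly beyond the scatter in either direction. Compound 3 is accordingly estimated to give in this assay 9500 nM, expected to lie between 3000 nM and 30000 nM.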

Compound 3, half-maximal inhibitory concentration: 7150 nM
Compound 3: middle estimate off by 1.3-fold (0.12 log units), on the high side, and the stated range covers the measured number.
By their numbers in this assay, from the lowest: compounds 3, 2 and 1 (each within the scatter of the next).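

In this assay, pyrrolidin-1-yl in place of anilino on the aromatic carbon meta to the (1H-indol-3-yl)sulfanyl group gives a 1.2-fold lower number from compound 2 to compound 3 (0.07 log units; within the scatter) and so separates the two groups by no clear margin, even though the exchange removes the hydrogen-bond donor of anilino and its six-membered aromatic ring. A second place can now be read as well: 4-chloro-2-methylphenyl in place of phenyl on an amide-type nitrogen gives a 1.6-fold lower number from compound 1 to compound 3 (0.20 log units; within the scatter) and likewise stays inside the scatter, so neither single change on the shared core moves the number clearly in this assay. Nothing measured in this series bears on why these steps are as small as they are.

On these data alone, whether a morpholin-4-yl ring, a primary amine or a carboxylic acid on the aromatic carbon that holds pyrrolidin-1-yl would produce a step beyond the scatter remains open. The same question stands for a phenyl ring carrying trifluoromethyl or nitrile on the amide-type nitrogen, and for any replacement of the (1H-indol-3-yl)sulfanyl group.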